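The source may hold more compounds than are shown below. What is called first, only, known or untested is meant among the compounds shown, and "the series" means these compounds.

Three compounds have been measured so far:

Compound 1, `O=C(NCCCCl)Nc1cccc(S(=O)(=O)Oc2ccc(O)cc2)c1`: in a functional assay on MCF7 cells (Homo sapiens) for cytotoxicity, read by sulforhodamine B assay, with a stated time of 48 h (a higher number here means a weaker inhibitor, a lower number a stronger inhibitor), compound 1 gives 51000 nM.
Compound 2, `Cc1ccccc1OS(=O)(=O)c1ccc(NC(=O)NCCCCl)cc1`: compound 2 gives 27000 nM.
Compound 3, `CCNC(=O)Nc1cccc(S(=O)(=O)Oc2ccc(O)cc2)c1`: compound 3 gives 64000 nM.

Compound 4, `CCNC(=O)Nc1ccc(S(=O)(=O)Oc2ccccc2C)cc1`, has not yet been measured in this assay. It is built from compound 2 by a single change, (hydrogen in place of chloromethyl on a saturated chain carbon, two bonds along the chain from an amide-type nitrogen). Compound 3 is built from compound 1 by the very same change at the same place, (hydrogen in place of chloromethyl on a saturated chain carbon, two bonds along the chain from an amide-type nitrogen), and that step is already measured: a 1.3-fold higher number from compound 1 to compound 3 (0.10 log units; within the scatter). Among the compounds with values here, the cores of compound 1 and compound 2 differ from each other, but that difference is not broken down here; the change on the chain is the only part the two pairs share. Because the measured step of a 1.3-fold higher number from compound 1 to compound 3 (0.10 log units; within the scatter) is small, the step from compound 2 to compound 4 is expected to be of similar size, a 1.3-fold higher number from compound 2 to compound 4 (0.11 log units; within the scatter). This expectation rests on one measured pair only, so it is held loosely. Compound 4 is then expected to give about 35000 nM in this assay, most likely falling between 15000 nM and 80000 nM.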

Compound 4, half-maximal inhibitory concentration: 4500 nM
Compound 4: middle estimate off by 7.8-fold (0.89 log units), on the high side; measured number below the stated range.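

Replacing the 3-chloropropyl group with ethyl gives, in this assay, a 6.0-fold lower number from compound 2 to compound 4 (0.78 log units; beyond the scatter), so on the core of compound 2 this change goes with a stronger inhibitor. Set beside the earlier pair, the same change does not carry over from one core to the other as a step of fixed size: the same change on two cores in this assay, a 1.3-fold higher number (0.10 log units; within the scatter) from compound 1 to compound 3 and a 6.0-fold lower number (0.78 log units; beyond the scatter) from compound 2 to compound 4, 7.5-fold (0.88 log units) apart, beyond the scatter of two such steps This shows that the size of the step depends on the core it is made on, but it rests on only two pairs and does not show which part of the cores matters, why the steps differ, or what would happen on a third core.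

Going by these compounds, it remains open whether the lower number for compound 4 comes from losing the chlorine or from shortening the chain, a question that a plain propyl group on both cores would address. Also open, on these data alone, is how other groups at this place, such as a longer chain or a chain ending in an amine or a carboxylic acid, would behave.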